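Furan-3-yl amide in the acetogenin-type series: expected growth inhibition

This account rests on a few compounds, and the source may have more. Where it says the series, first, only, none or still open, it means among the compounds named here.

Measured compounds:
- compound 1, `CCCCCCCCCCCC[C@@H](O)[C@H]1CC[C@H]([C@H](O)CCCCCCCCCCNC(=O)c2cncs2)O1`: 19100 nM
- compound 2, `CCCCCCCCCCCC[C@@H](O)[C@H]1CC[C@H]([C@H](O)CCCCCCCCCCNC(=O)c2ccsc2)O1`: 1000 nM
- compound 3, `CCCCCCCCCCCC[C@@H](O)[C@H]1CC[C@H]([C@H](O)CCCCCCCCCCNC(=O)c2ccco2)O1`: 18200 nM

In a functional assay on NCI-H522 cells (Homo sapiens) for inhibition, read by colorimetric assay and sulforhodamine B assay, with a stated time of 48 h (on this read-out lower numbers stand for stronger inhibition of growth and higher numbers for weaker inhibition of growth), compound 1 stands at the highest number of the three, with compound 3 close to it and compound 2 far lower. The step of a 19-fold lower number from compound 1 to compound 2 (1.28 log units; beyond the scatter) is large, whereas a 1.0-fold lower number from compound 1 to compound 3 (0.02 log units; within the scatter) lies within the scatter; accordingly an 18-fold higher number from compound 2 to compound 3 (1.26 log units; beyond the scatter) is large as well. The exchange of the five-membered aromatic ring on the carbonyl carbon can thus move this assay strongly or not at all.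

Compound 4, `CCCCCCCCCCCC[C@@H](O)[C@H]1CC[C@H]([C@H](O)CCCCCCCCCCNC(=O)c2ccoc2)O1`, is not yet measured. Its change from compound 1 is furan-3-yl in place of 1,3-thiazol-5-yl on a carbonyl carbon. Going by the values given here, no measured step covers this exact group. The entering furan-3-yl shares its single hetero atom with furan-2-yl of compound 3, where a 1.0-fold lower number from compound 1 to compound 3 (0.02 log units; within the scatter) showed nothing beyond the scatter, yet it is attached as the thiophen-3-yl of compound 2 is, where a 19-fold lower number from compound 1 to compound 2 (1.28 log units; beyond the scatter) was large. Weighing both, a moderate drop is expected, a 3.2-fold lower number from compound 1 to compound 4 (0.50 log units; beyond the scatter), so compound 4 is estimated at 6000 nM, between 1500 nM and 22000 nM.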

Compound 4, concentration for 50% growth inhibition: 10000 nM
Compound 4: middle estimate off by 1.7-fold (0.22 log units), on the low side; the measured number falls inside the stated range.
By their numbers in this assay, from the lowest: compound 2; then compounds 4, 3 and 1 (each within the scatter of the next).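

In this assay, furan-3-yl on a carbonyl carbon does not separate from the other two rings: a 1.9-fold lower number from compound 1 to compound 4 (0.28 log units; within the scatter) and a 1.8-fold lower number from compound 3 to compound 4 (0.26 log units; within the scatter) both lie within the scatter, so the two furan attachments cannot be told apart here. Sharing the attachment of thiophen-3-yl does not carry over its low number, as a 10-fold higher number from compound 2 to compound 4 (1.00 log units; beyond the scatter) is beyond the scatter, which leaves the thiophen-3-yl amide of compound 2 alone among the four and makes the ring hetero atom, not the attachment alone, the difference between compounds 2 and 4. No measurement at hand accounts for this separation.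

Open, on these data alone, is whether thiophen-2-yl would follow thiophen-3-yl or the furans. A phenyl ring on the same carbonyl carbon would test whether a five-membered ring is needed at all.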